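Working notes: pyrrolidin-1-yl for piperidin-1-yl on sulfonyl

The source may hold more compounds than are shown below. What is called first, only, known or untested is meant among the compounds shown, and "the series" means these compounds.

Measured so far in an ADME assay on HepG2 cells (Homo sapiens) for cytotoxicity, read by MTT assay, with a stated time of 48 h (on this read-out lower numbers stand for stronger inhibition and higher numbers for weaker inhibition), both values being limits:
- compound 1 `O=S(=O)(c1cccc(-c2ccc3ncnc(Nc4ccc(OCc5cccc(F)c5)c(Cl)c4)c3c2)c1)N1CCOCC1`: > 15000 nM
- compound 2 `O=S(=O)(c1cccc(-c2ccc3ncnc(Nc4ccc(OCc5cccc(F)c5)c(Cl)c4)c3c2)c1)N1CCCCC1`: > 15000 nM

Compound 2 gives > 15000 nM, which is a limit and not a number. Within the data shown here, the whole series so far sits at the limit of > 15000 nM in this assay, at which 2 of the 2 values shown sit.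

Compound 3 `O=S(=O)(c1cccc(-c2ccc3ncnc(Nc4ccc(OCc5cccc(F)c5)c(Cl)c4)c3c2)c1)N1CCCC1` carries pyrrolidin-1-yl in place of piperidin-1-yl on a sulfonyl sulfur.

Among the measured compounds shown here, the one measured step that bears on this change is a step that the two limits leave unreadable from compound 1 to compound 2, which also replaces a group on the sulfonyl sulfur. Its size cannot be read, so it gives no guide to magnitude or direction.

In this assay no step beyond the scatter is expected, and no direction, since compound 2 gives > 15000 nM. Compound 3 is expected to be reported as a limit too, more likely than not.

The estimated step is a step that the limit leaves unreadable from compound 2 to compound 3.

For compound 3 the estimated value is 20000 nM, with an expected range from 10000 nM to 40000 nM.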

Compound 3, half-maximal inhibitory concentration: > 15000 nM
Compound 3: a limit, no number (the forecaster's own chance of this, stated with the estimate: 75%); the middle value is on the limit's open side.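

No step among compound 1, compound 2 and compound 3 can be read in this assay, since all three give a limit and not a number: the limit of > 15000 nM in this assay, at which 3 of the 3 values shown sit.

The compounds shown leave open whether morpholin-4-yl, piperidin-1-yl and pyrrolidin-1-yl on a sulfonyl sulfur differ at all in this assay.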